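From 2-fluorobenzyl to 3-chlorobenzyl: expectations for compound 3

The source may report more compounds than this note shows. Statements on the series, on what has been measured and on what is new or still open speak of the compounds shown alone.

Within the data shown here, only two compounds have been measured so far in an ADME assay on cells (Astrocyte, Homo sapiens) for cytotoxicity, read by WST assay, with a stated time of 72 h; a lower number here means a stronger inhibitor, a higher number a weaker inhibitor. Among the measured compounds shown here, compound 2 `O=C(Nc1ccccc1F)Nc1cc2ncncc2cc1OCc1ccccc1F` gives 10000 nM, and this is the only exact number available. Compound 1 `O=C(Nc1cccc(F)c1)Nc1cc2ncncc2cc1OCc1cccc(Cl)c1` gives > 10000 nM, which is a limit of the assay and not a number.

The next compound, compound 3 `O=C(Nc1ccccc1F)Nc1cc2ncncc2cc1OCc1cccc(Cl)c1`, keeps most of compound 2 and changes one group: 3-chlorophenyl in place of 2-fluorophenyl on a saturated chain carbon bound to an oxygen on an aromatic ring. In plain words, 3-chlorophenyl stands in place of 2-fluorophenyl on a saturated chain carbon bound to an oxygen on an aromatic ring, so 2-fluorobenzyl becomes 3-chlorobenzyl.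

For the measured compounds named here, no measured pair yet shows what a single change does in this assay, so the forecast rests on little. Compound 3 shares its 3-chlorobenzyl with compound 1, whose reading of > 10000 nM is a limit. The expected result is no change at the digits printed from compound 2 to compound 3 (within the scatter), with no change beyond the usual scatter and no clear direction. Compound 3 could also be reported only as a limit. For compound 3 the estimated value is 10000 nM, with an expected range from 5000 nM to 20000 nM.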

Compound 3, half-maximal inhibitory concentration: 8700 nM
Beside the measured number, compound 3's estimate is 1.1-fold (0.06 log units) above it; the measured number falls inside the stated range.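

In this assay, among these compounds, this is the first step that isolates a single change: 3-chlorophenyl in place of 2-fluorophenyl on a saturated chain carbon bound to an oxygen on an aromatic ring gives a 1.1-fold lower number from compound 2 to compound 3 (0.06 log units; within the scatter), so this swap leaves the reading within the scatter. A second place can now be examined as well, since 2-fluorophenyl in place of 3-fluorophenyl on an amide-type nitrogen gives an at least 1.1-fold lower number from compound 1 to compound 3 (0.06 log units; that floor lies within the scatter), which sets only a floor on the size of that step. Compound 1 gives > 10000 nM, which is a limit and not a number, so the true size of the step at the amide-type nitrogen stays unknown: the limit of > 10000 nM in this assay, at which 1 of the 3 values shown sits.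

The compounds shown carry only fluorine- or chlorine-bearing phenyl groups at these two places, so a single swap of one halogen-bearing ring for another says little about groups of a different kind. On these data alone, whether an amine or a carboxylic acid on either ring, or a longer chain in place of the 3-chlorobenzyl, would shift the number beyond the scatter remains open.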